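The compounds below may be only part of what the source reports. "The series", "measured", "known", "first", "only" and "open" are said of these compounds alone.

Measured compounds:
compound 1 `COc1cc(N(C)CCN(C)C)c(NC(=O)/C=C\C(C)C)cc1Nc1nc(C)cc(-c2cn(C)c3ccccc23)n1`, 3550 nM
compound 2 `C=CC(=O)Nc1cc(Nc2nc(C)cc(-c3cn(C)c4ccc(F)cc34)n2)c(OC)cc1N(C)CCN(C)C`, 4280 nM
compound 3 `CC/C=C\C(=O)Nc1cc(Nc2nc(C)cc(-c3cn(C)c4ccc(F)cc34)n2)c(OC)cc1N(C)CCN(C)C`, 11000 nM

In a functional assay on HepG2 cells (Homo sapiens) for antiproliferative activity, read by MTT assay, with a stated time of 72 h (on this read-out higher numbers stand for weaker inhibition and lower numbers for stronger inhibition), compound 3 gives 11000 nM, the highest of the three numbers. Compound 2 gives 4280 nM and compound 1 gives 3550 nM; both gaps to compound 3 lie beyond the scatter.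

Compound 4 `COc1cc(N(C)CCN(C)C)c(NC(=O)/C=C\C(C)C)cc1Nc1nc(C)cc(-c2cn(C)c3ccc(F)cc23)n1` differs from compound 3 by methyl in place of hydrogen on a saturated chain carbon bound to a double-bonded chain carbon and a saturated chain carbon. For the measured compounds named here, the only measured step on this amide chain is a 2.6-fold higher number from compound 2 to compound 3 (0.41 log units; beyond the scatter), where a longer chain gave a higher number. Adding a further methyl is not covered by any measured pair. The same 3-methylbut-1-en-1-yl amide as in compound 4 is carried, however, by compound 1, which gives 3550 nM, a lower number than compound 3, though the two compounds also differ elsewhere. The step of a 1.7-fold lower number from compound 3 to compound 4 (0.23 log units; within the scatter) is therefore expected to be small, at most a modest move to a lower number or none beyond the scatter. Compound 4 is estimated at 6500 nM, within a range of 2500 nM to 16000 nM.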

Compound 4, half-maximal inhibitory concentration: 14000 nM
Compound 4: middle estimate off by 2.2-fold (0.33 log units), on the low side; low and high end bracket the measured number.
By their numbers in this assay, from the lowest: compounds 1 and 2 (each within the scatter of the next); then compounds 3 and 4 (each within the scatter of the next).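

Methyl in place of hydrogen on this saturated chain carbon, which turns but-1-en-1-yl into 3-methylbut-1-en-1-yl, makes no difference that can be told from the scatter (a 1.3-fold higher number from compound 3 to compound 4 (0.10 log units; within the scatter)). Against vinyl, however, the 3-methylbut-1-en-1-yl amide lies clearly apart (a 3.3-fold higher number from compound 2 to compound 4 (0.51 log units; beyond the scatter)), so on this evidence the step away from vinyl matters, while the added methyl does not register. For the compounds shown here, with this amide held fixed, fluoro can be read for the first time: fluoro in place of hydrogen on an aromatic carbon goes with a higher number, beyond the scatter (a 3.9-fold higher number from compound 1 to compound 4 (0.60 log units; beyond the scatter)).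

On these data alone, whether fluoro gives a step of the same size with a vinyl amide stays open, as does how a hydroxyl or a cyclopropyl group would read on this saturated chain carbon. No measurement at hand offers an explanation for any of these steps.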